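The compounds below may be only part of what the source reports. "The series", "measured", "known", "first", "only" and "open" are said of these compounds alone.

Within the data shown here, in a functional assay on HeLa cells (Homo sapiens) for antiproliferative activity, read by MTT assay, with a stated time of 72 h (on this read-out lower numbers stand for stronger inhibition and higher numbers for weaker inhibition), compound 1 `COc1cccc(N2C(=O)COc3ccc(-c4cnc5ccccc5c4)cc32)c1` gives 11400 nM, the only exact number so far. Compound 2 `COc1cccc(N2C(=O)COc3ccc(-c4ccc(O)cc4)cc32)c1` is reported as > 40000 nM, which is a limit of the assay and not a number. Compound 3 `O=C1COc2ccc(-c3cnc4ccccc4c3)cc2N1c1ccc(Cl)cc1` keeps the core of compound 1 and has 4-chlorophenyl in place of 3-methoxyphenyl on an amide-type nitrogen in a ring. No change at this place has yet been measured, so no shift beyond the usual scatter is expected in this assay. The expected change is a 1.2-fold higher number from compound 1 to compound 3 (0.09 log units; within the scatter). For compound 3 the estimate is 14000 nM, with an expected range of 5000 nM to 40000 nM.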

Compound 3, half-maximal inhibitory concentration: > 40000 nM
Compound 3: only a limit was reported (the forecaster's own chance of this, stated with the estimate: 15%); middle value at least 2.8-fold (0.45 log units) from the limit.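

In this assay, the first change measured at this place, 4-chlorophenyl in place of 3-methoxyphenyl on the amide-type nitrogen, gives an at least 3.5-fold higher number from compound 1 to compound 3 (0.54 log units; beyond the scatter). This shows that, with the core of compound 1 kept, this place does not accept every phenyl group alike. The value of compound 3 is a limit, so the full size of the step cannot be read because it is bounded by that limit: the limit of > 40000 nM in this assay, at which 2 of the 3 values shown sit.

The compounds shown do not separate the gain of chlorine from the loss of methoxy or the change of ring position. As far as these compounds go, how an amine or a carboxylic acid on this phenyl ring would read remains open.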